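From compound 2 to compound 4: one added methyl

A few compounds are considered here, and "the series" means these few. Any claim that something is new, unique, unknown or untested is made for them only; others in the source may bear on it.

Compound 1 `Brc1ccc2[nH]c(-c3cn(-c4ccccc4)nc3-c3ccccc3)nc2c1`, compound 2 `Cc1ccc2[nH]c(-c3cn(-c4ccccc4)nc3-c3ccccc3)nc2c1` and compound 3 `COc1ccc2[nH]c(-c3cn(-c4ccccc4)nc3-c3ccccc3)nc2c1` share one core. In an ADME assay on HaCaT cells (Homo sapiens) for cytotoxicity, read by MTT assay, with a stated time of 48 h (a lower number here means a stronger inhibitor, a higher number a weaker inhibitor), compound 1 gives > 50000 nM, which is a limit. Compound 2 gives > 50000 nM, also a limit. Compound 3 gives > 50000 nM, again a limit. Compound 2 therefore stands at the limit of > 50000 nM in this assay, at which 3 of the 3 values shown sit, with no number of its own.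

Compound 4 `Cc1cc2nc(-c3cn(-c4ccccc4)nc3-c3ccccc3)[nH]c2cc1C` carries methyl in place of hydrogen on an aromatic carbon, methyl in place of hydrogen on an aromatic carbon. Among the compounds with values here, three steps bear on this: a step that the two limits leave unreadable from compound 1 to compound 2, a step that the two limits leave unreadable from compound 1 to compound 3 and a step that the two limits leave unreadable from compound 2 to compound 3. None of them gives a size, so no step beyond the scatter is expected in this assay. The expected change is a number no higher from compound 2 to compound 4 (the limit leaves the size open). For compound 4 the estimated value is 50000 nM, with an expected range of 25000 nM to 100000 nM.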

Compound 4, half-maximal inhibitory concentration: > 50000 nM
Compound 4: no number, only a limit (the forecaster's own chance of this, stated with the estimate: 85%); the middle value sits exactly at the limit.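

No size can be read for the step between compound 2 and compound 4, as both stand only as limits: the limit of > 50000 nM in this assay, at which 4 of the 4 values shown sit.

Going by these compounds, whether any change on the shared core gives a number of its own in this assay remains open.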